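The source may report more compounds than this note shows. Statements on the series, on what has been measured and on what is new or still open speak of the compounds shown alone.

Measured in a functional assay on MT4 cells (Homo sapiens) for cytotoxicity; a higher number here means that more compound is tolerated, a lower number that less compound is tolerated:
Compound 1 `CC(C)Sc1nc(O)cc(C(C)c2c(Cl)cccc2Cl)n1`: 117000 nM
Compound 2 `CC(c1cc(O)nc(SC2CCCCC2)n1)c1c(Cl)cccc1Cl`: > 200000 nM

For compound 2, the entry > 200000 nM is a limit of the assay and not a number. Compound 3 `CC(c1cc(O)nc(SC2CCCCC2)n1)c1c(F)cccc1F` keeps the cyclohexyl on sulfur and carries 2,6-difluorophenyl in place of 2,6-dichlorophenyl (2,6-difluorophenyl in place of 2,6-dichlorophenyl on a saturated chain carbon bound to an aromatic carbon and a saturated chain carbon). Among the compounds with values here, the only measured step, an at least 1.7-fold higher number from compound 1 to compound 2 (0.23 log units; that floor lies within the scatter), has cyclohexyl in place of isopropyl on a sulfur. It does not touch the 2,6-dichlorophenyl group, so no measurement gives a size for this swap. Within the data shown here, with compound 1 at 117000 nM as the only firm number, no change beyond the scatter is expected in this assay, in either direction. The estimated step, an at least 1.3-fold lower number from compound 2 to compound 3 (0.12 log units; that floor lies within the scatter), is therefore small. Compound 3 is estimated at 150000 nM, with an expected range of 70000 nM to 200000 nM.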

Compound 3, half-maximal cytotoxic concentration: > 200000 nM
Compound 3: no number, only a limit (the forecaster's own chance of this, stated with the estimate: 50%); middle value at least 1.3-fold (0.12 log units) away from the limit.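

Within the data shown here, compound 2 and compound 3 each give only a limit of the assay, so no step from one to the other can be read in this assay: the limit of > 200000 nM in this assay, at which 2 of the 3 values shown sit.

The compounds shown leave open whether 2,6-difluorophenyl in place of 2,6-dichlorophenyl changes the tolerated concentration at all.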